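Selenocyanate and diselenide carbamates on MCF7 cells

The compounds below may be only part of what the source reports. "The series", "measured", "known", "first", "only" and "open" are said of these compounds alone.

Three measured members of the series sit close together. In a functional assay on MCF7 cells (Homo sapiens) for cytotoxicity, read by MTT assay, with a stated time of 72 h (on this read-out lower numbers stand for higher toxicity in this test and higher numbers for lower toxicity in this test), compound 1 `C=CCOC(=O)Nc1ccc([Se]C#N)cc1` gives 71200 nM; compound 2 `O=C(Nc1ccc([Se][Se]c2ccc(NC(=O)OCc3ccc([N+](=O)[O-])cc3)cc2)cc1)OCc1ccc([N+](=O)[O-])cc1` gives 85000 nM and compound 3 `CCCCOC(=O)Nc1ccc([Se][Se]c2ccc(NC(=O)OCCCC)cc2)cc1` gives 75200 nM. The gaps among these three numbers lie within the scatter, so compound 1 cannot be set apart from either neighbour in this assay.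

Compound 4 `CCCCOC(=O)Nc1ccc([Se]C#N)cc1` has not been measured. It differs from compound 1 by propyl in place of vinyl on a saturated chain carbon bound to an oxygen next to a carbonyl group. For the measured compounds named here, no measured pair shows this change, and compound 3, which carries the same butyl carbamate, is not separable from compound 1 in this assay. The step of a 1.1-fold higher number from compound 1 to compound 4 (0.02 log units; within the scatter) is therefore expected to stay within the scatter. Compound 4 is estimated at 75000 nM, with a range of 40000 nM to 140000 nM.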

Compound 4, concentration lethal to 50% of the cells: 59700 nM
The estimate for compound 4 lay 1.3-fold (0.10 log units) above the measured number; measured number inside the range.
By their numbers in this assay, from the lowest: compounds 4, 1, 3 and 2 (each within the scatter of the next).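

In this assay, propyl in place of vinyl on a saturated chain carbon bound to an oxygen next to a carbonyl group gives a 1.2-fold lower number from compound 1 to compound 4 (0.08 log units; within the scatter) and so does not separate the two compounds. At this position, then, removing the double bond outside aromatic rings and adding one carbon leaves the read-out within the scatter. No supporting evidence bears on this step.

Still open, on these data alone, is whether a longer chain, or an amine or carboxylic acid on this chain, would shift the number beyond the scatter.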